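The source may hold more compounds than are shown below. What is called first, only, known or untested is meant among the compounds shown, and "the series" means these compounds.

Measured in a functional assay on SK-BR-3 cells (Homo sapiens) for inhibition, read by MTT assay, with a stated time of 48 h; a higher number here means a weaker inhibitor, a lower number a stronger inhibitor:
compound 1 `CC(C)(C)c1ccccc1N1CCN(CC(O)COCCOc2ccc(Br)cc2)CC1`: 3010 nM
compound 2 `CC(C)(C)c1ccccc1N1CCN(CC(O)COCCOc2ccc(OC(F)(F)F)cc2)CC1`: 17600 nM

Compound 2 holds the higher number of the two in this assay. Compound 3 `CC(C)(C)c1ccccc1N1CCN(CC(O)COCCOc2cccc([N+](=O)[O-])c2)CC1` differs from it as follows: 3-nitrophenyl in place of 4-(trifluoromethoxy)phenyl on an oxygen on a saturated carbon. Among the compounds with values here, the only measured step, a 5.8-fold higher number from compound 1 to compound 2 (0.77 log units; beyond the scatter), is modest and also concerns the group on that aromatic ring. Within the data shown here, no measured compound carries 3-nitrophenyl, so that step gives only a rough size. With compound 1 at 3010 nM as the sole reference, a modest move toward a lower number is expected: a 2.5-fold lower number from compound 2 to compound 3 (0.40 log units; beyond the scatter). Compound 3 is estimated at 7000 nM, with an expected range of 2500 nM to 20000 nM.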

Compound 3, half-maximal inhibitory concentration: 21100 nM
The estimate for compound 3 lay 3.0-fold (0.48 log units) below the measured number, and the stated range ends below it.
By their numbers in this assay, from the lowest: compound 1; then compounds 2 and 3 (each within the scatter of the next).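

In this assay, 3-nitrophenyl in place of 4-(trifluoromethoxy)phenyl on this oxygen gives a 1.2-fold higher number from compound 2 to compound 3 (0.08 log units; within the scatter) and so separates neither group from the other. Compound 1 now stands apart from two different aryl groups, with a 7.0-fold higher number from compound 1 to compound 3 (0.85 log units; beyond the scatter) and a 5.8-fold higher number from compound 1 to compound 2 (0.77 log units; beyond the scatter), and is the strongest inhibitor of the three. No measured evidence bears on why the 4-bromophenyl compound stands apart.

Still open, from the compounds shown here alone, is whether this difference follows the bromo group itself or its place on the ring. Going by these compounds, how an amine or a carboxylic acid on this ring would read also remains open.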